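The source may report more compounds than this note shows. Statements on the series, on what has been measured and on what is new or still open speak of the compounds shown alone.

Three analogues that share one core and differ only in the group on a saturated chain carbon bound to a carbonyl carbon have been tested in a toxicity assay on microsomes from liver (Homo sapiens) for metabolic stability, read by LC-MS, using NADPH, tested at 1 uM; a higher number here means faster removal of the compound, a lower number slower removal. There compound 1 (`CCOc1ncc(-c2nc(C(F)(F)F)sc2N2CCN(C(=O)Cn3ccc4cccnc43)[C@H](C)C2)cn1`) gives 316 mL.min-1.g-1, compound 2 (`CCOc1ncc(-c2nc(C(F)(F)F)sc2N2CCN(C(=O)Cn3ccc4cnccc43)[C@H](C)C2)cn1`) gives 656 mL.min-1.g-1 and compound 3 (`CCOc1ncc(-c2nc(C(F)(F)F)sc2N2CCN(C(=O)Cn3nc(C)cc3C)[C@H](C)C2)cn1`) gives 184 mL.min-1.g-1. The place of compound 3 among them shows in two steps: a 1.7-fold lower number from compound 1 to compound 3 (0.23 log units; within the scatter), and a 3.6-fold lower number from compound 2 to compound 3 (0.55 log units; beyond the scatter). It therefore cannot be told apart from compound 1 but sits under compound 2.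

Compound 4 (`CCOc1ncc(-c2nc(C(F)(F)F)sc2N2CCN(C(=O)Cn3nc(C)nc3C)[C@H](C)C2)cn1`) has not yet been measured. It differs from compound 3 in that same place: 3,5-dimethyl-1H-1,2,4-triazol-1-yl in place of 3,5-dimethyl-1H-pyrazol-1-yl on a saturated chain carbon bound to a carbonyl carbon. Among the compounds with values here, no measured pair tests this exact exchange. The closest evidence is the other exchanges at this place, namely those two steps and a 2.1-fold higher number from compound 1 to compound 2 (0.32 log units; beyond the scatter), and none of them goes beyond a modest size. A small step is therefore expected here too. The lean towards a lower number is a judgment about the structural change, and these compounds do not test it. The expected change is a 1.5-fold lower number from compound 3 to compound 4 (0.17 log units; within the scatter), and it may well not be distinguishable from the scatter. For compound 4 the estimate is 125 mL.min-1.g-1, with an expected range from 60 mL.min-1.g-1 to 240 mL.min-1.g-1.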

Compound 4, intrinsic clearance in microsomes: < 10 mL.min-1.g-1
Compound 4 was reported as a limit; the forecaster's own chance of this, stated with the estimate: 3%; middle value at least 12-fold (1.09 log units) from the limit.
By their numbers in this assay, from the lowest: compounds 3 and 1 (each within the scatter of the next); then compound 2. At a limit, below all of these: compound 4.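

In this assay, the place on a saturated chain carbon bound to a carbonyl carbon proved far more sensitive than the earlier exchanges suggested: 3,5-dimethyl-1H-1,2,4-triazol-1-yl in place of 3,5-dimethyl-1H-pyrazol-1-yl, two groups of 7 heavy atoms, gives an at least 18-fold lower number from compound 3 to compound 4 (1.26 log units; beyond the scatter), a large step where none had gone beyond a modest size. Against the groups of 9 heavy atoms the distance is greater still, with an at least 31-fold lower number from compound 1 to compound 4 (1.49 log units; beyond the scatter) and an at least 65-fold lower number from compound 2 to compound 4 (1.81 log units; beyond the scatter). The result for compound 4 is a limit of the assay and not a number: the limit of < 10 mL.min-1.g-1 in this assay, at which 1 of the 4 values shown sits.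

As far as these compounds go, how an unsubstituted 1H-1,2,4-triazol-1-yl or a 1H-tetrazol-1-yl would behave at this place stays open, as does whether the two methyl groups of 3,5-dimethyl-1H-1,2,4-triazol-1-yl have any part in the result. These compounds also do not show what lies behind the step, or whether it would carry over to a core other than the shared one.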